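The source may report more compounds than this note shows. Statements on the series, on what has been measured and on what is new or still open speak of the compounds shown alone.

Series notes. Compound 1 `CCC1(Cc2ccccc2)OS(=O)(=O)C=C1OCc1ccc(C)cc1` has been run in an ADME assay on HEL cells (Homo sapiens) for cytotoxicity, with a stated time of 3 days; on this read-out higher numbers stand for lower toxicity in this test and lower numbers for higher toxicity in this test. In this assay compound 1 gives >= 16000 nM, which is a limit of the assay and not a number, so compound 1 stands only at a limit among the three values shown (the limit of >= 16000 nM in this assay, at which 1 of the 3 values shown sits). Compound 2 `CCC1(CC)OS(=O)(=O)C=C1OCc1ccccc1` gives > 400000 nM in this assay, also a limit rather than a number (the limit of > 400000 nM in this assay, at which 1 of the 3 values shown sits). Compound 3 `CC(C)C1(Cc2ccccc2)OS(=O)(=O)C=C1OCc1ccccc1` gives >= 80000 nM in this assay, again a limit (the limit of >= 80000 nM in this assay, at which 1 of the 3 values shown sits). Within the data shown here, no two of the measured compounds differ in one place, so no measured step is available, and all three readings sit at limits. Compound 4 `CCC1(Cc2ccccc2)OS(=O)(=O)C=C1OCc1ccc(Br)cc1` is not yet measured. It differs from compound 1 by bromo in place of methyl on an aromatic carbon. With bromo in place of methyl on an aromatic carbon, no change beyond the usual scatter is expected in this assay. The expected step that the limit leaves unreadable from compound 1 to compound 4 is taken as flat. Compound 4 is expected to give 20000 nM in this assay, with a range from 8000 nM to 80000 nM, and a limit rather than a number is likely to be reported.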

Compound 4, minimum cytotoxic concentration: 80000 nM
Compound 4: middle estimate off by 4.0-fold (0.60 log units), on the low side, within the range that was stated.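

Compound 1 stands only at a limit of the assay, so no step to compound 4 can be read in this assay: the limit of >= 16000 nM in this assay, at which 1 of the 4 values shown sits.

The compounds shown leave open whether bromo in place of methyl on an aromatic carbon shifts the reading in this assay at all.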